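Ethyl to isopentyl at the upper clearance limit

This account rests on a few compounds, and the source may have more. Where it says the series, first, only, none or still open, it means among the compounds named here.

In an ADME assay on microsomes from liver (Homo sapiens) for metabolic stability, read by LC-MS, using NADPH (a lower number here means slower removal, a higher number faster removal of the compound), compound 1 (`CCOC(=O)c1cnc(N2CCN(C(=O)NS(=O)(=O)c3ccc(Cl)s3)CC2)c(Cl)c1`) reads > 70000 mL.min-1.g-1, which is a limit and not a number. Compound 2 (`CCOC(=O)c1cnc(N2CCN(C(=O)NS(=O)(=O)c3ccc(C)cc3)CC2)c(Cl)c1`) reads > 70000 mL.min-1.g-1, also a limit. Compound 3 (`CCOC(=O)c1cc(C#N)c(N2CCN(C(=O)NS(=O)(=O)Cc3ccccc3)CC2)nc1C`) reads < 13000 mL.min-1.g-1, likewise a limit. Compound 4 (`CC(C)CCOC(=O)c1cnc(N2CCN(C(=O)NS(=O)(=O)c3ccc(Cl)s3)CC2)c(Cl)c1`) differs from compound 1 by isopropyl in place of hydrogen on a saturated chain carbon, two bonds along the chain from an oxygen next to a carbonyl group, which turns ethyl into isopentyl. Among the compounds with values here, the one measured step, a step that the two limits leave unreadable from compound 1 to compound 2, places 4-methylphenyl in place of 5-chlorothiophen-2-yl on a sulfonyl sulfur, away from this chain, and offers no size to carry over. The estimated change is a step that the limit leaves unreadable from compound 1 to compound 4, so no step beyond the scatter is expected in this assay. Compound 4 is expected near 80000 mL.min-1.g-1, with an estimated range from 40000 mL.min-1.g-1 to 160000 mL.min-1.g-1.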

Compound 4, intrinsic clearance in microsomes: > 70000 mL.min-1.g-1
Compound 4: only a limit was reported (the forecaster's own chance of this, stated with the estimate: 75%); the middle value does not contradict the limit.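

Compound 4 gives > 70000 mL.min-1.g-1, which is a limit and not a number. Within the data shown here, compound 1 also reads only a limit, so no step between the two can be read. The compounds shown leave open the size of the change from ethyl to isopentyl in this assay.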